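A few compounds are considered here, and "the series" means these few. Any claim that something is new, unique, unknown or untested is made for them only; others in the source may bear on it.

Measured compounds:
- compound 1 `CC(C)NCc1cn(CC(=O)Nc2sc3c(c2C(N)=O)CCCC3)nc1C(F)(F)F`: 3160 nM
- compound 2 `CN(C)Cc1cn(CC(=O)Nc2sc3c(c2C(N)=O)CCCC3)nc1C(F)(F)F`: 501 nM
- compound 3 `NCc1cn(CC(=O)Nc2sc3c(c2C(N)=O)CCCC3)nc1C(F)(F)F`: 794 nM

In an assay on isolated protein with metabotropic glutamate receptor 1 (Homo sapiens) as the target (a higher number here means that more compound is needed for the effect, a lower number that less compound is needed), compound 3 gives 794 nM, the second highest of the three numbers. Its nearest neighbour is compound 2, and the gap a 1.6-fold higher number from compound 2 to compound 3 (0.20 log units; within the scatter) lies within the scatter, so no order between these two can be read. The gap to compound 1 is larger: a 4.0-fold lower number from compound 1 to compound 3 (0.60 log units; beyond the scatter), which is beyond the scatter.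

Compound 4 `COCCNCc1cn(CC(=O)Nc2sc3c(c2C(N)=O)CCCC3)nc1C(F)(F)F` differs from compound 3 by 2-methoxyethyl in place of hydrogen on an amine nitrogen. The step that bears on this most directly is a 4.0-fold lower number from compound 1 to compound 3 (0.60 log units; beyond the scatter), showing that removing the isopropyl from the amine nitrogen lowers the number; read the other way, putting a branched alkyl on that nitrogen raises it. The comparison of compound 2 and compound 3, a 1.6-fold higher number from compound 2 to compound 3 (0.20 log units; within the scatter), shows that two methyl groups on the same nitrogen leave the number within the scatter of the free amine. A 2-methoxyethyl chain is neither case exactly; it adds more than the methyls but is unbranched. A modest rise in this assay is therefore expected, smaller than the isopropyl step, and possibly no change beyond the scatter.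

For compound 4 the expected value in this assay is 1500 nM, with a range of 600 nM to 4000 nM, corresponding to an expected step of a 1.9-fold higher number from compound 3 to compound 4 (0.28 log units; within the scatter).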

Compound 4, half-maximal effective concentration: 1580 nM
Estimate against measurement, compound 4: 1.1-fold (0.02 log units) below, and the stated range covers the measured number.
By their numbers in this assay, from the lowest: compounds 2, 3, 4 and 1 (each within the scatter of the next, the first and the last beyond it).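

In this assay, 2-methoxyethyl on the amine nitrogen cannot be told apart from hydrogen, a 2.0-fold higher number from compound 3 to compound 4 (0.30 log units; within the scatter), or from isopropyl, a 2.0-fold lower number from compound 1 to compound 4 (0.30 log units; within the scatter), so compound 4 falls within the scatter of both, even though the step between those two lies beyond it. Within the data shown here, the one step from compound 4 beyond the scatter is modest, a 3.2-fold higher number from compound 2 to compound 4 (0.50 log units; beyond the scatter), so (2-methoxyethyl)amino can be separated from dimethylamino at this place, which the free amine of compound 3 could not. No measurement available here explains these steps.

The compounds shown leave open whether the oxygen of the 2-methoxyethyl chain matters at all, a question that a plain butyl chain or a longer 3-methoxypropyl chain on the same nitrogen would address. Also open, as far as these compounds go, is whether the lower number of compound 2 extends to other amines with a fully substituted nitrogen, such as a morpholine or a pyrrolidine, or to an N-methyl-N-(2-methoxyethyl)amine.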